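A few compounds are considered here, and "the series" means these few. Any claim that something is new, unique, unknown or untested is made for them only; others in the source may bear on it.

Notes on the series, step from compound 3 to compound 4.

Compound 1 `c1cncc(N2C[C@@H]3CCNC[C@@H]32)c1` gives 410 nM in a functional assay on HEK293 cells for agonist activity at Neuronal acetylcholine receptor; alpha4/beta2 (Homo sapiens), read by FLIPR; on this read-out lower numbers stand for an effect already at smaller amounts and higher numbers for an effect only at larger amounts of compound. Its mirror image, compound 2 `c1cncc(N2C[C@H]3CCNC[C@H]32)c1`, gives 1400 nM; the step of a 3.4-fold higher number from compound 1 to compound 2 (0.53 log units; beyond the scatter) rests on the fact that the two differ only in configuration as drawn (the fact that compounds 1 and 2 differ only in the configuration as drawn). Compound 3 `N#Cc1cncc(N2C[C@@H]3CCNC[C@@H]32)c1` gives 2190 nM and stands highest of the three numbers; the step from the unsubstituted parent is a 5.3-fold higher number from compound 1 to compound 3 (0.73 log units; beyond the scatter). Compound 4 `N#Cc1cncc(N2C[C@H]3CCNC[C@H]32)c1` is not yet measured. The change is the two compounds have the same atoms and bonds and differ only in configuration as drawn: 2 of 2 stereo elements differ (all stereocentres are inverted: mirror images); a stereocentre at a saturated ring carbon is drawn S in compound 3 and R in compound 4; a stereocentre at a saturated ring carbon is drawn R in compound 3 and S in compound 4, in other words the same inversion of both ring stereocentres that separates compound 1 from compound 2. Going by the values given here, the only measured step that bears on it is therefore a 3.4-fold higher number from compound 1 to compound 2 (0.53 log units; beyond the scatter), which was beyond the scatter and in the direction of a higher number. Carrying that step over, compound 4 is expected to show a higher number than compound 3, by roughly a 3.2-fold higher number from compound 3 to compound 4 (0.50 log units; beyond the scatter). Compound 4 is thus estimated at 7000 nM, with a likely range from 2500 nM to 20000 nM; the upper end allows that the assay may report only a limit.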

Compound 4, half-maximal effective concentration: 1930 nM
For compound 4 the middle estimate is 3.6-fold (0.56 log units) above the measured one, and the stated range ends above it.
By their numbers in this assay, from the lowest: compound 1; then compounds 2, 4 and 3 (each within the scatter of the next).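

In this assay, the inversion of both ring stereocentres in the presence of the cyano group gives a 1.1-fold lower number from compound 3 to compound 4 (0.05 log units; within the scatter), so the separation between the mirror images compound 1 and compound 2 does not carry over to this pair. Cyano in place of hydrogen on an aromatic carbon gives a 1.4-fold higher number from compound 2 to compound 4 (0.14 log units; within the scatter), so the size of this step depends on the configuration of the core: the same change on two cores in this assay, a 5.3-fold higher number (0.73 log units; beyond the scatter) from compound 1 to compound 3 and a 1.4-fold higher number (0.14 log units; within the scatter) from compound 2 to compound 4, 3.9-fold (0.59 log units) apart, beyond the scatter of two such steps. The two changes therefore do not act independently across these four compounds.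

Going by these compounds, whether another group on the same aromatic carbon, such as methoxy or an amine, would also remove the separation between mirror images remains open. The values also do not explain why the cyano step depends on configuration, and they cover only this one receptor read-out.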